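From Nitro to Methoxy: Expecting Compound 4

The source may hold more compounds than are shown below. What is called first, only, known or untested is meant among the compounds shown, and "the series" means these compounds.

Compound 1 `CCOC(=O)C1=Cc2ccccc2OC1(OCc1cn(-c2ccc(F)cc2)nn1)C(F)(F)F`: 7300 nM
Compound 2 `O=C(O)C1=Cc2ccccc2OC1(OCc1cc(-c2ccc([N+](=O)[O-])cc2)no1)C(F)(F)F`: > 150000 nM
Compound 3 `CCOC(=O)C1=Cc2ccccc2OC1(OCc1cn(-c2ccc(F)c(Cl)c2)nn1)C(F)(F)F`: 26300 nM

Of the compounds shown here, three have been tested in a functional assay on A549 cells (Homo sapiens) for inhibition, read by MTT assay, with a stated time of 24 h; on this read-out higher numbers stand for weaker inhibition and lower numbers for stronger inhibition. Within the data shown here, compound 1 gives 7300 nM and compound 3 gives 26300 nM; the one single-point step known, a 3.6-fold higher number from compound 1 to compound 3 (0.56 log units; beyond the scatter), is a chloro in place of hydrogen on an aromatic carbon. Compound 2 reaches only a limit of the measurement, (the limit of > 150000 nM in this assay, at which 1 of the 3 values shown sits), so no number is known for it; it stands at that limit rather than among the measured values.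

Compound 4 `COc1ccc(-c2cc(COC3(C(F)(F)F)Oc4ccccc4C=C3C(=O)O)on2)cc1` differs from compound 2 by methoxy in place of nitro on an aromatic carbon. Among the measured compounds shown here, no measured step covers this change: the step from compound 1 to compound 3 alters a different group on compounds built differently, and it was modest. As far as these compounds go, because compound 2 shows only (the limit of > 150000 nM in this assay, at which 1 of the 3 values shown sits), the starting point itself is unknown, and the expected step of an at least 1.2-fold lower number from compound 2 to compound 4 (0.09 log units; that floor lies within the scatter) can only be guessed with wide bounds. Compound 4 is estimated at about 120000 nM, expected between 30000 nM and 300000 nM, and may again reach only the limit.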

Compound 4, half-maximal inhibitory concentration: 36200 nM
For compound 4 the middle estimate is 3.3-fold (0.52 log units) above the measured one; the range from low to high includes it.
By their numbers in this assay, from the lowest: compound 1; then compounds 3 and 4 (each within the scatter of the next). At a limit, above all of these: compound 2.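

In this assay, putting methoxy in place of nitro on the aromatic carbon para to a large group brings a measurable result, and the change is an at least 4.1-fold lower number from compound 2 to compound 4 (0.61 log units; beyond the scatter). As far as these compounds go, compound 2 has a limit and not a number, so the true size of this step stays open: the limit of > 150000 nM in this assay, at which 1 of the 4 values shown sits. Even so, the group at this place can clearly shift the read-out, which the earlier chloro step, made on compounds built differently, could not show.

Only nitro and methoxy are shown at this place, so they establish no wider pattern across groups. From the compounds shown here alone, whether an amine or a hydroxyl group there would give a lower or higher number remains open, as does how this change would read with the ethyl ester of compound 1 in place of the carboxylic acid.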